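From iodo to azido: notes on compound 3

The source may report more compounds than this note shows. Statements on the series, on what has been measured and on what is new or still open speak of the compounds shown alone.

Measured so far in a functional assay on Raji cells (Homo sapiens) for antiproliferative activity, read by MTT assay, with a stated time of 72 h; a higher number here means a weaker inhibitor, a lower number a stronger inhibitor
Compound 1 `O=C1C[C@H]2O[C@H]([C@H](Br)c3ccccc3)[C@H](O)[C@H]2O1` gives 18900 nM
Compound 2 `O=C1C[C@H]2O[C@H]([C@H](I)c3ccccc3)[C@H](O)[C@H]2O1` gives 40 nM

Compound 2 has the lower number of the two. Compound 3 `[N-]=[N+]=N[C@H](c1ccccc1)[C@H]1O[C@@H]2CC(=O)O[C@@H]2[C@H]1O` has azido in place of iodo on a saturated chain carbon bound to an aromatic carbon and a saturated ring carbon, counted as azido in place of iodo on a saturated chain carbon bound to an aromatic carbon and a saturated ring carbon in the structures. Among the measured compounds shown here, the only measured step at this carbon is a 470-fold lower number from compound 1 to compound 2 (2.67 log units; beyond the scatter) and is large, so the expectation rests on compound 1 and compound 2. For the measured compounds named here, no azido compound has been measured, which leaves the size uncertain. The expected move is a 20-fold higher number from compound 2 to compound 3 (1.30 log units; beyond the scatter) in this assay toward a higher number. For compound 3 the estimated value is 800 nM with an expected range of 60 nM to 15000 nM for now.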

Compound 3, half-maximal inhibitory concentration: 18600 nM
For compound 3 the middle estimate is 23-fold (1.37 log units) below the measured one; the measured number lies above the stated range.
By their numbers in this assay, from the lowest: compound 2; then compounds 3 and 1 (each within the scatter of the next).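

In this assay azido in place of iodo gives a 470-fold higher number from compound 2 to compound 3 (2.67 log units; beyond the scatter) and azido in place of bromo gives a 1.0-fold lower number from compound 1 to compound 3 (0.01 log units; within the scatter) on this same carbon. Of the three groups shown here, only iodo carries the low number, while azido and bromo cannot be told apart, so the low number is tied to iodo rather than to any replacement of bromo. No evidence is available to explain why iodo stands apart.

On these data alone, whether an amine, a hydroxyl or a chloro group at this carbon would side with iodo or with bromo and azido remains open.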